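Replacing naphthalen-1-yl in compound 2 with 3-fluorophenyl

The compounds below may be only part of what the source reports. "The series", "measured", "known", "first", "only" and "open" are said of these compounds alone.

In a functional assay on HL-60 cells (Homo sapiens) for inhibition, read by CCK-8 assay, with a stated time of 48 h, tested at 20 uM (a higher number here means more inhibition of growth at the concentration tested, a lower number less inhibition of growth), compound 2 `N#C/C(=C\c1ccccc1OS(=O)(=O)c1ccccc1[N+](=O)[O-])C(=O)Nc1nnc(Cc2cccc3ccccc23)s1` reads 23% and compound 1 `N#C/C(=C\c1ccccc1OS(=O)(=O)c1ccc([N+](=O)[O-])cc1)C(=O)Nc1nnc(Cc2cccc3ccccc23)s1` reads 18%, a gap inside the scatter (a number 5 percentage points higher from compound 1 to compound 2 (within the scatter)). Compound 3 `N#C/C(=C\c1ccccc1OS(=O)(=O)c1ccc(F)cc1)C(=O)Nc1nnc(Cc2cccc3ccccc23)s1` reads 12% and separates from compound 2 alone (a number 11 percentage points lower from compound 2 to compound 3 (beyond the scatter)), not from compound 1 (a number 6 percentage points lower from compound 1 to compound 3 (within the scatter)).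

Compound 4 `N#C/C(=C\c1ccccc1OS(=O)(=O)c1ccccc1[N+](=O)[O-])C(=O)Nc1nnc(Cc2cccc(F)c2)s1` changes another part of the structure: 3-fluorophenyl in place of naphthalen-1-yl on a saturated chain carbon bound to an aromatic carbon. All three measured steps lie on the sulfonyl side, and all three compounds keep naphthalen-1-yl, so none of them tests this change directly. Going by these compounds, no step beyond the scatter is therefore expected in this assay, and the direction stays open. The expected change is small (a number 3 percentage points lower from compound 2 to compound 4 (within the scatter)). Compound 4 is estimated at 20% (range 7% to 38%).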

Compound 4, percent growth inhibition at one concentration: 23%
Estimate against measurement, compound 4: 3 percentage points below, and the stated range covers the measured number.
By their numbers in this assay, from the lowest: compounds 3, 1, 2 and 4 (each within the scatter of the next, the first and the last beyond it).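

In this assay, replacing naphthalen-1-yl with 3-fluorophenyl on a saturated chain carbon bound to an aromatic carbon gives no change at the digits printed from compound 2 to compound 4 (within the scatter). For the compounds shown here, this is the first step read on this side of the shared core. With 2-nitrophenyl held on the sulfonyl sulfur, one aromatic ring in place of two leaves no readable difference at this single concentration, and no supporting data offer an explanation for this result.

Open, going by these compounds, is whether 3-fluorobenzyl gives the same reading with 4-nitrophenyl or 4-fluorophenyl on the sulfonyl sulfur. Also open, on these data alone, is how a carboxylic acid or an amine in place of 3-fluorophenyl would read.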